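Thiourea-linked sulfonamide: swapping the aniline substituent

The compounds below may be only part of what the source reports. "The series", "measured", "known", "first", "only" and "open" are said of these compounds alone.

Compound 3 `NS(=O)(=O)c1ccc(NC(=S)Nc2ccc3ncnc(Nc4ccc(Cl)c(C(F)(F)F)c4)c3c2)cc1` gives 4500 nM in a functional assay on A549 cells (Homo sapiens) for antiproliferative activity, read by MTT assay, with a stated time of 72 h (on this read-out higher numbers stand for weaker inhibition and lower numbers for stronger inhibition), the lowest of the two numbers in the set. The nearest is compound 2 `CCc1ccc(Nc2ncnc3cc(OC)c(OCCCCC(=O)Nc4ccc(S(N)(=O)=O)cc4)cc23)cc1`, which gives 12100 nM in this assay. Compound 1 `COc1cc2ncnc(Nc3cccc(F)c3)c2cc1OCCCCC(=O)Nc1ccc(S(N)(=O)=O)cc1` is reported only as a limit in this assay, > 40000 nM, and the reading of this compound is the limit of > 40000 nM in this assay, at which 1 of the 3 values shown sits. Compound 4 `CCc1ccc(Nc2ncnc3ccc(NC(=S)Nc4ccc(S(N)(=O)=O)cc4)cc23)cc1` keeps the thiourea-linked sulfonamide of compound 3 and changes the aniline: 4-ethylphenyl in place of 4-chloro-3-(trifluoromethyl)phenyl on a nitrogen on an aromatic ring.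

Among the measured compounds shown here, one measured step touches the same position. It is an at least 3.3-fold lower number from compound 1 to compound 2 (0.51 log units; beyond the scatter), on the amide-linked scaffold rather than the thiourea, and it starts from a limit, so its true size is only bounded from one side. For the measured compounds named here, the group entering there is the same 4-ethylphenyl that enters in compound 4, but the group leaving differs, 3-fluorophenyl against 4-chloro-3-(trifluoromethyl)phenyl, and no pair in the set compares those two directly. Taken together, the expectation for compound 4 is a step of no more than modest size in either direction, and a 1.3-fold higher number from compound 3 to compound 4 (0.12 log units; within the scatter) is the estimated change. Compound 4 is accordingly expected to give about 6000 nM in this assay, with a plausible span from 2000 nM to 20000 nM.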

Compound 4, half-maximal inhibitory concentration: 24600 nM
The estimate for compound 4 lay 4.1-fold (0.61 log units) below the measured number, outside the stated range (above it).
By their numbers in this assay, from the lowest: compound 3; then compound 2; then compound 4. At a limit, above all of these: compound 1.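

In this assay, replacing 4-chloro-3-(trifluoromethyl)phenyl with 4-ethylphenyl on the thiourea-linked sulfonamide weakens inhibition (a 5.5-fold higher number from compound 3 to compound 4 (0.74 log units; beyond the scatter)), so this position responds to the change on the thiourea series. The only earlier step at this position ran the other way with the same 4-ethylphenyl entering on the amide-linked scaffold (an at least 3.3-fold lower number from compound 1 to compound 2 (0.51 log units; beyond the scatter)), a step bounded from one side only, so 4-ethylphenyl does not lower the number in both series shown, although the group leaving also differs between the two steps. Nothing measured for these compounds accounts for the size of the new step or for its opposite direction.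

Still open, going by these compounds, is how much of the step belongs to the chloro substituent and how much to the trifluoromethyl substituent; a 4-chlorophenyl or a 3-(trifluoromethyl)phenyl group on the same nitrogen would separate the two. Also open, on these data alone, is whether the difference in direction belongs to the linker, which would take one aniline group carried on both the thiourea and the amide-linked scaffold to settle.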